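Swapping methoxy for chloro with no starting number

The source may report more compounds than this note shows. Statements on the series, on what has been measured and on what is new or still open speak of the compounds shown alone.

Compound 1 `COc1ccc(NC(=S)NC2CC(C)(C)Oc3ccc(Br)cc32)cc1` offers no starting point on the numbers: in a functional assay on B16-F10 cells (Mus musculus) for inhibition, read by MTT assay, with a stated time of 72 h (a lower number here means a stronger inhibitor, a higher number a weaker inhibitor), compound 1 is recorded as "not determined" (no result reported). Going by the values given here, the only number available comes from compound 2 `CC1(C)CC(NC(=O)Nc2ccccc2Cl)c2cc(Br)ccc2O1`, and in this assay compound 2 gives 22000 nM.

The structural change under study is small: chloro in place of methoxy on an aromatic carbon. It puts chloro in place of methoxy on an aromatic carbon, para to a large group, and this yields compound 3 `CC1(C)CC(NC(=S)Nc2ccc(Cl)cc2)c2cc(Br)ccc2O1`. Among the compounds with values here, without a value for compound 1, no step can actually be measured here. Even so, a swap of this kind is expected to produce no step beyond the usual scatter in this assay, and no direction can be favoured. The estimate therefore leans on compound 2 at 22000 nM, with a wide margin. Compound 3 is expected at about 15000 nM, with an estimated range from 5000 nM to 45000 nM.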

Compound 3, half-maximal inhibitory concentration: 7000 nM
Beside the measured number, compound 3's estimate is 2.1-fold (0.33 log units) above it; low and high end bracket the measured number.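

In this assay compound 3 gives 7000 nM while compound 1 carries no number, so no step can be read between compound 1 and compound 3. From the compounds shown here alone, how the swap from methoxy to chloro alone shifts inhibition stays open. Nothing shown here offers an explanation for the value of compound 3.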